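Working notes: the step from compound 2 to compound 3

This account rests on a few compounds, and the source may have more. Where it says the series, first, only, none or still open, it means among the compounds named here.

Measured in an ADME assay on BJ cells (Homo sapiens) for cytotoxicity, with a stated time of 72 h; on this read-out higher numbers stand for an effect only at larger amounts of compound and lower numbers for an effect already at smaller amounts:
- compound 1 `C=C[C@@](C)(/C=C/c1ccc(O)c(/C=C/C(N)=O)c1)CCC=C(C)C`: > 36600 nM (a limit)
- compound 2 `C=C[C@@](C)(/C=C/c1ccc(O)c(/C=C/c2ccc(F)cc2)c1)CCC=C(C)C`: > 36600 nM (a limit)

Compound 2 stands only at a limit, > 36600 nM, and has no number. Compound 1 is also known only as a limit, > 36600 nM. Within the data shown here, the whole series so far therefore rests on (the limit of > 36600 nM in this assay, at which 2 of the 2 values shown sit).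

Compound 3 `C=C[C@@](C)(/C=C/c1ccc(O)c(/C=C/c2ccc(Cl)c(Cl)c2)c1)CCC=C(C)C` carries 3,4-dichlorophenyl in place of 4-fluorophenyl on a double-bonded chain carbon bound to a double-bonded chain carbon.

Among the measured compounds shown here, the one measured step that bears on this place is a step that the two limits leave unreadable from compound 1 to compound 2, so it offers no size to carry over and no direction. With nothing readable to build on, no change beyond the scatter is expected in this assay, and another limit is the most likely report. The expected step is an at least 1.0-fold lower number from compound 2 to compound 3 (0.00 log units; that floor lies within the scatter). A shift towards lower numbers stays possible, so the expected range is kept wide on that side. For compound 3 the estimate is 36000 nM, with an expected range of 10000 nM to 75000 nM.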

Compound 3, half-maximal effective concentration: > 13000 nM
Compound 3 gave a limit, no number; the forecaster's own chance of this, stated with the estimate: 65%; the middle value is on the limit's open side.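

In this assay compound 3 is known only as a limit, > 13000 nM. Among these compounds, no step among compound 1, compound 2 and compound 3 can be read, as all three values are limits. Going by these compounds, whether carbamoyl, 4-fluorophenyl and 3,4-dichlorophenyl differ at this place at all, and in which direction, stays open.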